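A few compounds are considered here, and "the series" means these few. Any claim that something is new, unique, unknown or untested is made for them only; others in the source may bear on it.

Among the measured compounds shown here, compound 1 `O=C(O)c1csc([C@H]2CC[C@@H]3[C@@H](/C=C/[C@@H](O)COc4ccccc4)[C@H](O)C[C@@H]3O2)n1` is the one member of this small set for which a number rather than a limit is recorded. For the measured compounds named here, in a functional assay on Chem1 cells for agonist activity at prostaglandin F2-alpha receptor (Homo sapiens), read by fluorescence and calcium flux (a higher number here means that more compound is needed for the effect, a lower number that less compound is needed), compound 1 gives 32 nM, and that is the only numerical value available for comparison. Compound 2 `O=C(O)c1csc([C@H]2CC[C@@H]3[C@@H](CCCOc4ccccc4)[C@H](O)C[C@@H]3O2)n1`, which carries a saturated chain in place of the unsaturated hydroxylated one, reaches only the limit of the measurement. In this assay compound 2 gives > 10000 nM, and this is a limit of the measurement, not a number; it is the limit of > 10000 nM in this assay, at which 1 of the 2 values shown sits. Compound 3 `O=C(O)c1csc([C@H]2CC[C@@H]3[C@@H](/C=C/CCOc4ccccc4)[C@H](O)C[C@@H]3O2)n1` has not yet been measured in this assay. It differs from compound 1 by a single change: hydrogen in place of hydroxy on a saturated chain carbon bound to a double-bonded chain carbon and a saturated chain carbon. Going by the values given here, since no pair of measured compounds differing in just one place is available, the size of the step can only be judged from the whole of the set. Compound 3 is expected to lose considerably, with an estimated step of a 63-fold higher number from compound 1 to compound 3 (1.80 log units; beyond the scatter) that lies well beyond the scatter, because compound 2 gives > 10000 nM once both the hydroxy and the double bond are gone. Compound 3 is therefore estimated to give 2000 nM, within a range from 300 nM to 10000 nM.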

Compound 3, half-maximal effective concentration: 380 nM
Compound 3: middle estimate off by 5.3-fold (0.72 log units), on the high side, and the stated range covers the measured number.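

In this assay, among the compounds shown here, the change from 1-hydroxy-2-phenoxyethyl to 2-phenoxyethyl is the first change at this position that can be read on its own, and it gives a 12-fold higher number from compound 1 to compound 3 (1.07 log units; beyond the scatter), so the hydroxy on this saturated chain carbon accounts for a large part of the potency of compound 1. Even so, with the double bond kept, compound 3 still gives a number and not a limit, which shows that losing the hydroxy alone does not take the response out of the measured range. Compound 2 differs from compound 3 in more than one place and gives only a limit of the measurement, not a number, so it puts no size on any further single change: the limit of > 10000 nM in this assay, at which 1 of the 3 values shown sits.

On these data alone, whether a methoxy, a fluorine or an amine on this same carbon would keep the potency of compound 1 remains open, as does the effect of the opposite configuration of the hydroxy. Also open, as far as these compounds go, is what the double bond contributes on its own, which a saturated chain of the same length carrying the same hydroxy would show.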